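The compounds below may be only part of what the source reports. "The series", "measured", "known", "first", "only" and "open" are said of these compounds alone.

The series shares one core, seen in compound 1 `Cc1cccc(Cn2cc(COc3ccc4c(=O)ccoc4c3)nn2)c1`, compound 2 `Cc1ccc(Cn2cc(COc3ccc4c(=O)ccoc4c3)nn2)cc1` and compound 3 `N#Cc1ccc(Cn2cc(COc3ccc4c(=O)ccoc4c3)nn2)cc1`. In a functional assay on A549 cells (Homo sapiens) for cytotoxicity, read by MTT assay, with a stated time of 48 h (on this read-out higher numbers stand for weaker inhibition and lower numbers for stronger inhibition), compound 1 gives 20300 nM. Compound 2 gives 50700 nM in this assay. Compound 3 reaches only a limit of this assay, > 100000 nM, and so stands at the weak end of the numbers shown, being the one of three values that sits at that limit (the limit of > 100000 nM in this assay, at which 1 of the 3 values shown sits). Compound 4 `O=c1ccoc2cc(OCc3cn(Cc4ccc([N+](=O)[O-])cc4)nn3)ccc12` differs from compound 3 by nitro in place of cyano on an aromatic carbon. Among the measured compounds shown here, two measured steps bear on it: an at least 4.9-fold higher number from compound 1 to compound 3 (0.69 log units; beyond the scatter) and an at least 1.9-fold higher number from compound 2 to compound 3 (0.29 log units; that floor lies within the scatter). Both raised the number on the way to compound 3, and neither involves a nitro group. For compound 4 the step that the limit leaves unreadable from compound 3 to compound 4 is expected, leaving it at or past the limit. Compound 4 is therefore estimated at 150000 nM, between 50000 nM and 500000 nM.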

Compound 4, half-maximal inhibitory concentration: > 100000 nM
Compound 4: a limit, no number (the forecaster's own chance of this, stated with the estimate: 70%); the middle value lies beyond the limit too.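

Compound 4 shows that nitro on this aromatic carbon, para to a large group, gives no readable number in this assay, so the steps that end at two limits cannot be read. Against the methyl compounds, the readable steps are an at least 4.9-fold higher number from compound 1 to compound 4 (0.69 log units; beyond the scatter) and an at least 1.9-fold higher number from compound 2 to compound 4 (0.29 log units; that floor lies within the scatter). Compound 3 and compound 4 now both stand at a limit of this assay: the limit of > 100000 nM in this assay, at which 2 of the 4 values shown sit.

The compounds shown leave open how nitro and cyano rank beyond that limit. They also leave open whether an amine or a carboxylic acid at this place would give a readable number.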